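This account rests on a few compounds, and the source may have more. Where it says the series, first, only, none or still open, it means among the compounds named here.

Compound 1 `N#Cc1ccc(Nc2nc(Oc3ccnc4ccccc34)nc(N3CCN(c4ccccc4Cl)CC3)n2)cc1C(F)(F)F`. In a functional assay on DU-145 cells (Homo sapiens) for cytotoxicity, read by sulforhodamine B assay, with a stated time of 48 h (on this read-out higher numbers stand for lower toxicity in this test and lower numbers for higher toxicity in this test), compound 1 gives > 100000 nM, a limit of the assay.
Compound 2 `CC1CC(C)CN(c2nc(Nc3ccc(C#N)c(C(F)(F)F)c3)nc(Oc3ccnc4ccccc34)n2)C1`. In this assay compound 2 gives > 100000 nM, again a limit of the assay.
Compound 3 `N#Cc1ccc(Nc2nc(Oc3ccnc4ccccc34)nc(N3CCN(c4cccc(C(F)(F)F)c4)CC3)n2)cc1C(F)(F)F`. In this assay compound 3 gives > 100000 nM, also a limit of the assay.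

Compound 3 therefore stands at the limit, as do the two other measured compounds (the limit of > 100000 nM in this assay, at which 3 of the 3 values shown sit). Going by the values given here, the one measured step that touches compound 3, a step that the two limits leave unreadable from compound 1 to compound 3, is unreadable in size, since both of its ends are limits. The change now followed is ethyl in place of 3-(trifluoromethyl)phenyl on an amine nitrogen in a ring, which gives compound 4 `CCN1CCN(c2nc(Nc3ccc(C#N)c(C(F)(F)F)c3)nc(Oc3ccnc4ccccc34)n2)CC1`. Among the compounds with values here, no measured step reads on this change: the only comparison available, from compound 1 to compound 3, shows no number at either end, and compound 2 likewise shows only a limit. The expectation for compound 4 in this assay is thus no step beyond the scatter, a step that the limit leaves unreadable from compound 3 to compound 4, and most probably another limit. Compound 4 is estimated at 150000 nM, with a range from 40000 nM to 600000 nM.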

Compound 4, concentration lethal to 50% of the cells: > 100000 nM
Compound 4 was reported as a limit; the forecaster's own chance of this, stated with the estimate: 80%; the middle value lies beyond the limit too.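

In this assay compound 4 gives > 100000 nM, a limit of the assay, so its steps from compound 1, compound 2 and compound 3 cannot be read: the limit of > 100000 nM in this assay, at which 4 of the 4 values shown sit. The compounds shown leave open whether any of these changes alters the result in this assay, as none of them gives a number.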